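The source may report more compounds than this note shows. Statements on the series, on what has been measured and on what is new or still open speak of the compounds shown alone.

Compound 1 `Nc1nc2cc(C(F)(F)F)ccn2c1-c1ccc(O)cc1`: > 100000 nM
Compound 2 `Cc1ccn2c(-c3ccc(O)cc3)c(N)nc2c1`: > 100000 nM

In an assay on isolated protein for inhibition of ubiquitin carboxyl-terminal hydrolase 1 (Homo sapiens) (a lower number here means a stronger inhibitor, a higher number a weaker inhibitor), compound 1 gives > 100000 nM, which is a limit of the assay and not a number. Compound 2 gives > 100000 nM in this assay, likewise a limit. The step that the two limits leave unreadable from compound 1 to compound 2 is thus unreadable, and compound 2 stands at the limit of > 100000 nM in this assay, at which 2 of the 2 values shown sit. Compound 3 `Nc1nc2cc(C3CCNCC3)ccn2c1-c1ccc(O)cc1` differs from compound 2 by piperidin-4-yl in place of methyl on an aromatic carbon. No readable measured step bears on this change, so no direction beyond the scatter can be expected from the numbers shown. Compound 3 is estimated at 50000 nM, expected between 3000 nM and 200000 nM, an expected step of an at least 2.0-fold lower number from compound 2 to compound 3 (0.30 log units; that floor lies within the scatter).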

Compound 3, half-maximal inhibitory concentration: > 100000 nM
Compound 3: no number, only a limit; the forecaster's own chance of this, stated with the estimate: 55%; middle value at least 2.0-fold (0.30 log units) away from the limit.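

In this assay compound 3 gives > 100000 nM, a limit of the assay and not a number. Within the data shown here, no step among compound 1, compound 2 and compound 3 can be read. The compounds shown leave open whether trifluoromethyl, methyl and piperidin-4-yl differ at all in their effect at this place, as all three compounds sit at one limit: the limit of > 100000 nM in this assay, at which 3 of the 3 values shown sit.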